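The source may report more compounds than this note shows. Statements on the series, on what has been measured and on what is new or still open speak of the compounds shown alone.

Measured so far:

compound 1, `CC(C)(C)OC(=O)N1CCC(CCCNc2ccc3c(c2)S(=O)(=O)CC3)CC1`: "not determined" (no result reported) in a functional assay on CHO-K1 cells for agonist activity at Glucose-dependent insulinotropic receptor (Mus musculus), read by HTRF and cAMP accumulation, with a stated time of 30 min; on this read-out lower numbers stand for smaller maximal responses and higher numbers for larger maximal responses
compound 2, `CC(C)(C)OC(=O)N1CCC(CCCNc2ccc3c(c2)C(=O)NC3)CC1`: 97%
compound 3, `COC(=O)c1cnc(N2CCC(CCCNc3ccc4c(c3)OCC4=O)CC2)nc1`: 67%

Compound 3 holds the lower of the two numbers recorded. Its nearest neighbour is compound 2, whose maximal response lies higher by a gap beyond the usual scatter; compound 1 carries no number at all. Among the compounds with values here, compound 2 differs from compound 3 both in the core and in the group on the amine nitrogen, so no single-change step connects the two measured values.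

The next member, compound 4, `CC(C)c1nsc(N2CCC(CCCNc3ccc4c(c3)OCC4=O)CC2)n1`, keeps the core of compound 3 and alters only the group on the amine nitrogen in a ring:

3-isopropyl-1,2,4-thiadiazol-5-yl in place of 5-(methoxycarbonyl)pyrimidin-2-yl on an amine nitrogen in a ring

Within the data shown here, no measured step of this kind exists, so the size of the change in this assay is open. The expectation is a small upward movement, quite possibly staying within the scatter rather than beyond it. Compound 4 is estimated at 75% with a range from 50% to 100%. The step this expectation implies is a number 8 percentage points higher from compound 3 to compound 4 (within the scatter).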

Compound 4, largest response reached (Emax), in percent of the reference or control that the assay uses: 93%
For compound 4 the middle estimate is 18 percentage points below the measured one, and the stated range covers the measured number.
By their numbers in this assay, from the lowest: compound 3; then compounds 4 and 2 (each within the scatter of the next).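

In this assay the group on the amine nitrogen in a ring gives its first readable step, a number 26 percentage points higher from compound 3 to compound 4 (beyond the scatter), so with the core held constant this position alone can shift the maximal response. On this core, the 5-(methoxycarbonyl)pyrimidin-2-yl group is therefore not needed for the higher response, which compound 4 reaches with 3-isopropyl-1,2,4-thiadiazol-5-yl instead. The two groups differ at once in ring size, hetero atoms and the double bond outside aromatic rings, and no measurement at hand ties the step to any one of these features.

On these data alone, whether the step follows the five-membered ring or the isopropyl group remains open, and a pyrimidin-2-yl bearing an isopropyl group would separate the two. Also open, as far as these compounds go, are how a carboxylic acid in place of the methoxycarbonyl would read and whether the step carries over to the core of compound 2.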